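A Stability Estimate for Compound 3

The compounds below may be only part of what the source reports. "The series", "measured", "known", "first", "only" and "open" are said of these compounds alone.

compound 1 `O=C(N1CC[C@](c2ccc(C(F)(C(F)(F)F)C(F)(F)F)cc2)(S(=O)(=O)c2ccc(F)cc2)C1)C12CCC(C(=O)O)(CC1)OC2` – "not determined" (no result reported)
compound 2 `CS(=O)(=O)C1CCC(C(=O)N2CC[C@](c3ccc(C(F)(C(F)(F)F)C(F)(F)F)cc3)(S(=O)(=O)c3ccc(F)cc3)C2)CC1` – 88%; 100% (2 entries)

In an ADME assay on microsomes from liver (Homo sapiens) for metabolic stability, with a stated time of 10 min (on this read-out higher numbers stand for a more stable compound and lower numbers for a less stable compound), compound 1 stands without a single number, its entry reading "not determined" (no result reported) in the record. Only compound 2 has numbers, and its repeated entries (the several entries of compound 2 in this assay, 88%; 100% (2 entries)) lie high on this read-out. The next compound is compound 3 `O=C(N1CC[C@](c2ccc(C(F)(C(F)(F)F)C(F)(F)F)cc2)(S(=O)(=O)c2ccc(F)cc2)C1)C1(F)CCS(=O)(=O)CC1`, and the change is a group of 9 heavy atoms (5 carbon, 2 oxygen, 1 fluorine, 1 sulfur; one six-membered non-aromatic ring with 1 hetero atom) in place of a group of 11 heavy atoms (8 carbon, 3 oxygen; one six-membered non-aromatic ring of carbon only, one six-membered non-aromatic ring with 1 hetero atom), on a carbonyl carbon in the core of compound 1: a 4-fluoro-1,1-dioxothian-4-yl group enters on a carbonyl carbon. Compound 1 offers no starting value, so no size or direction of a step from it can be stated. Compound 3 is instead expected to lie close to compound 2 (88%; 100% (2 entries)), which shares that core, with no difference beyond the scatter. For compound 3 the percent remaining in this assay is estimated at 90% (expected range 72% to 100%).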

Compound 3, percent of the compound remaining: 100%
Estimate against measurement, compound 3: 10 percentage points below; the measured number falls inside the stated range.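

In this assay, for the compounds shown here, compound 3 gives 100%, but compound 1 has no single number to set against it, so no step between compound 1 and compound 3 can be read. The compounds shown leave open how the 4-fluoro-1,1-dioxothian-4-yl group, taken alone, bears on the percent of compound remaining.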